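A few compounds are considered here, and "the series" means these few. Any claim that something is new, unique, unknown or untested is made for them only; others in the source may bear on it.

Among the measured compounds shown here, in a functional assay on A549 cells (Homo sapiens) for cytotoxicity, read by MTT assay, with a stated time of 72 h (on this read-out lower numbers stand for stronger inhibition and higher numbers for weaker inhibition), compound 1 `CN(C)Cc1ccc2nc(NC(=O)N/N=C/c3cn(Cc4ccccc4Cl)c4ccccc34)sc2c1` gives 1080 nM, the lower of the two numbers measured so far, while compound 2 `CN(C)Cc1ccc2nc(NC(=O)N/N=C/c3c[nH]c4ccccc34)sc2c1` gives 3300 nM. Compound 3 `CCN(CC)Cc1ccc2nc(NC(=O)N/N=C/c3cn(Cc4ccccc4Cl)c4ccccc34)sc2c1` has diethylamino in place of dimethylamino on a saturated chain carbon bound to an aromatic carbon. For the measured compounds named here, the only measured step, a 3.1-fold higher number from compound 1 to compound 2 (0.49 log units; beyond the scatter), lies at a different place and does not touch this amine, so no measured step bears directly on the change. No shift beyond the scatter is therefore expected in this assay, and the expected step is a 1.0-fold higher number from compound 1 to compound 3 (0.01 log units; within the scatter). For compound 3, the estimated value is 1100 nM, with an expected range of 500 nM to 2400 nM.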

Compound 3, half-maximal inhibitory concentration: 1390 nM
Compound 3: middle estimate off by 1.3-fold (0.10 log units), on the low side; measured number inside the range.
By their numbers in this assay, from the lowest: compounds 1 and 3 (each within the scatter of the next); then compound 2.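

In this assay the change from dimethylamino to diethylamino, on a saturated chain carbon bound to an aromatic carbon, gives a 1.3-fold higher number from compound 1 to compound 3 (0.11 log units; within the scatter). Among the compounds shown here, this is the first reading at this position, which the earlier pair left untouched, and here 5 heavy atoms in place of 3 bring no shift beyond the scatter. Nothing available explains this result. Still open, from the compounds shown here alone, is how a ring amine such as morpholine, or a primary amine, would read at this position. Going by these compounds, it is also open whether hydrogen in place of 2-chlorobenzyl on the aromatic nitrogen would act the same way alongside diethylamino.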